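Swapping 4-bromophenyl for 2-methoxyphenyl on compound 2

The source may report more compounds than this note shows. Statements on the series, on what has been measured and on what is new or still open speak of the compounds shown alone.

Going by the values given here, only two measured compounds anchor this series so far. In a functional assay on HepG2 cells (Homo sapiens) for cytotoxicity, read by sulforhodamine B assay, with a stated time of 48 h (on this read-out higher numbers stand for weaker inhibition and lower numbers for stronger inhibition), compound 1 (`COc1cc(/C=C/C(=O)c2ccc(N)c(-c3ccc(F)cc3)c2)cc(Br)c1O`) gives 4730 nM and compound 2 (`O=C(/C=C/c1ccc(Br)cc1)c1cccc(-c2cccc(F)c2)c1`) gives 9920 nM as the higher of the two numbers, with a gap beyond the usual scatter. Among the compounds with values here, these two compounds differ in more than one place, so no single-change step is available as a guide.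

Compound 3 (`COc1ccccc1/C=C/C(=O)c1cccc(-c2cccc(F)c2)c1`) differs from compound 2 by 2-methoxyphenyl in place of 4-bromophenyl on a double-bonded chain carbon bound to a double-bonded chain carbon and carries 2-methoxyphenyl in place of 4-bromophenyl on a double-bonded chain carbon bound to a double-bonded chain carbon.

With compound 2 at the top of the measured range at 9920 nM in this assay the expected move is modest and toward a lower number. The expected step of a 1.4-fold lower number from compound 2 to compound 3 (0.15 log units; within the scatter) stays within the scatter. Compound 3 is estimated at 7000 nM (2500 nM to 20000 nM).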

Compound 3, half-maximal inhibitory concentration: 15400 nM
For compound 3 the middle estimate is 2.2-fold (0.34 log units) below the measured one; low and high end bracket the measured number.
By their numbers in this assay, from the lowest: compound 1; then compounds 2 and 3 (each within the scatter of the next).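

Going by these compounds alone, compound 2 to compound 3 is the first single-change step: in this assay, 2-methoxyphenyl in place of 4-bromophenyl on a double-bonded chain carbon bound to a double-bonded chain carbon gives a 1.6-fold higher number from compound 2 to compound 3 (0.19 log units; within the scatter). At this place, then, the read-out does not separate the two groups, even though the exchange removes a bromine, brings in an oxygen and takes the hydrogen-bond acceptor count of the group from 0 to 1. No measurement shown here accounts for this step.

On these data alone, whether the same exchange gives a comparable step on the core of compound 1 remains open. Also open, as far as these compounds go, is whether an amine or a carboxylic acid in place of the methoxy group on this aromatic ring would move the number beyond the scatter.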